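A Hydroxypyrrolidine Variant on the Amine Side Chain

The source may hold more compounds than are shown below. What is called first, only, known or untested is meant among the compounds shown, and "the series" means these compounds.

Compound 1, `CC1CCN(CCCOc2ccc3c(c2)C(=O)N(C)CC3)CC1`, gives 32 nM in an assay on cerebellum for displacement of a labelled ligand from histamine H1 receptor (Cavia porcellus), read by scintillation counting, with a stated time of 60 min; a higher number here means a weaker inhibitor, a lower number a stronger inhibitor.
Compound 2, `CC1CCCN1CCCOc1ccc2c(c1)C(=O)N(C)CC2`, gives 26 nM.
Compound 3, `CN1CCc2ccc(OCCCN3CCC(=O)CC3)cc2C1=O`, gives 176 nM.

Among these three, compound 1 stands with the second highest number. Its nearest neighbour is compound 2, the step of a 1.2-fold lower number from compound 1 to compound 2 (0.09 log units; within the scatter) lying within the scatter, so no order between them can be read. For the measured compounds named here, the furthest is compound 3, reached by a 5.5-fold higher number from compound 1 to compound 3 (0.74 log units; beyond the scatter), and the same pattern appears in a 6.8-fold higher number from compound 2 to compound 3 (0.83 log units; beyond the scatter): the one compound whose ring carries an oxygen on a saturated chain carbon, three bonds along the chain from an oxygen on an aromatic ring, gives the clearly higher number.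

Compound 4, `CN1CCc2ccc(OCCCN3CCC(O)C3)cc2C1=O`, changes compound 1 by 3-hydroxypyrrolidin-1-yl in place of 4-methylpiperidin-1-yl on a saturated chain carbon, three bonds along the chain from an oxygen on an aromatic ring. As in compound 3, an oxygen-bearing ring replaces a methyl-bearing ring, though here as a hydroxyl rather than a carbonyl and on a five-membered ring, which compound 2 shows to be tolerated. The steps to compound 3 are the ones that bear on this change. Compound 4 is therefore expected to give a higher number by an estimated step of a 3.1-fold higher number from compound 1 to compound 4 (0.49 log units; beyond the scatter). Compound 4 is estimated at 100 nM, with a range from 40 nM to 300 nM.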

Compound 4, inhibition constant: 112 nM
Compound 4: middle estimate off by 1.1-fold (0.05 log units), on the low side; low and high end bracket the measured number.
By their numbers in this assay, from the lowest: compounds 2 and 1 (each within the scatter of the next); then compounds 4 and 3 (each within the scatter of the next).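

In this assay, the 3-hydroxypyrrolidin-1-yl group falls with the 4-oxopiperidin-1-yl group rather than with the two methyl-bearing rings: the steps from both methyl-bearing compounds lie beyond the scatter (a 3.5-fold higher number from compound 1 to compound 4 (0.54 log units; beyond the scatter); a 4.3-fold higher number from compound 2 to compound 4 (0.63 log units; beyond the scatter)), whereas the step between the two oxygen-bearing compounds lies within it (a 1.6-fold lower number from compound 3 to compound 4 (0.20 log units; within the scatter)), so no order can be read between them. Compound 2 and compound 4 both carry a five-membered ring at this place on the chain, so among these four compounds the higher number follows the oxygen-bearing groups, as a hydroxyl or a carbonyl and in either ring size, with no compound going against that pattern. No measured finding is available to explain this shift.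

The compounds shown leave open what an unsubstituted pyrrolidin-1-yl, a 4-hydroxypiperidin-1-yl or a ring bearing a methoxy group would give at this place, and so whether the hydroxyl or the loss of the methyl carries the step. Also open, on these data alone, is whether the same step would hold on a longer chain between the aromatic oxygen and the ring nitrogen.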